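This account rests on a few compounds, and the source may have more. Where it says the series, first, only, none or still open, it means among the compounds named here.

Of the compounds shown here, three built on one shared core have been measured in an ADME assay (liver) for metabolic stability, with Liver microsome (Rattus norvegicus) as the target, using microsomes and NADPH, with a stated time of 30 min; a lower number here means slower removal, a higher number faster removal of the compound. Compound 1 `CC#C[C@H]1CN(S(=O)(=O)c2ccc(N)nc2)CCN1c1ccc(C(=O)NC)cc1` gives 41 mL.min-1.g-1. Compound 2 `CC#C[C@H]1CN(S(=O)(=O)c2ccc(N)nc2)CCN1c1ccc([S+](C)[O-])cc1` gives 17 mL.min-1.g-1 in this assay. Compound 3 `CC#C[C@H]1CN(S(=O)(=O)c2ccc(N)nc2)CCN1c1ccc(S(C)(=N)=O)cc1` reaches only a limit of this assay, < 14 mL.min-1.g-1, so no exact number is known for it (the limit of < 14 mL.min-1.g-1 in this assay, at which 1 of the 3 values shown sits). The steps of an at least 2.9-fold lower number from compound 1 to compound 3 (0.46 log units; beyond the scatter) and an at least 1.2-fold lower number from compound 2 to compound 3 (0.08 log units; that floor lies within the scatter) both run into that limit, which places compound 3 at the low edge of the numbers shown. Compound 4 `CC#C[C@H]1CN(S(=O)(=O)c2ccc(N)nc2)CCN1c1ccc([C@](O)(CO)C(F)(F)F)cc1` has not yet been measured. It differs from compound 3 by a group of 8 heavy atoms (3 carbon, 2 oxygen, 3 fluorine; no ring) in place of a group of 4 heavy atoms (1 carbon, 1 nitrogen, 1 oxygen, 1 sulfur; no ring), on an aromatic carbon. Within the data shown here, two measured steps touch the same position: a 2.4-fold lower number from compound 1 to compound 2 (0.38 log units; beyond the scatter) and an at least 2.9-fold lower number from compound 1 to compound 3 (0.46 log units; beyond the scatter), each modest and each toward a lower number. Among the measured compounds shown here, the group entering in compound 4 resembles neither the group of compound 2 nor that of compound 3, and no measured step covers a change of this kind, so the direction stays open. The expected step is an at least 1.4-fold higher number from compound 3 to compound 4 (0.15 log units; that floor lies within the scatter). Compound 4 is therefore estimated to give 20 mL.min-1.g-1, within a range from 8 mL.min-1.g-1 to 50 mL.min-1.g-1, in this assay.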

Compound 4, intrinsic clearance in microsomes: < 14 mL.min-1.g-1
Compound 4 was reported as a limit (the forecaster's own chance of this, stated with the estimate: 30%); middle value at least 1.4-fold (0.15 log units) from the limit.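

Compound 4 also reaches only a limit in this assay, not an exact number: the limit of < 14 mL.min-1.g-1 in this assay, at which 2 of the 4 values shown sit.

Replacing methylcarbamoyl with 1,2-dihydroxy-1-(trifluoromethyl)ethyl, which contains no sulfur, gives an at least 2.9-fold lower number from compound 1 to compound 4 (0.46 log units; beyond the scatter), so among these compounds a low number at this position does not require a sulfur-containing group, as compound 2 and compound 3 alone might have suggested. The comparison with compound 2 gives only a floor, an at least 1.2-fold lower number from compound 2 to compound 4 (0.08 log units; that floor lies within the scatter), while the step between compound 3 and compound 4 cannot be read because both are limits.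

On these data alone, how far compound 3 and compound 4 lie below the limit therefore stays open, as does which part of the new group matters. As far as these compounds go, it is also open how a plain hydroxymethyl group or a carboxylic acid would read at this position.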